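Putting a methoxy back on the chain

This account rests on a few compounds, and the source may have more. Where it says the series, first, only, none or still open, it means among the compounds named here.

Compound 1 `COC[C@H](C)[C@H](C)C(c1ccc(O)c(OC)c1)c1ccc(O)c(OC)c1` gives 82000 nM
Compound 2 `COc1cc(C(c2ccc(O)c(OC)c2)[C@@H](C)[C@@H](C)CF)ccc1O` gives 38000 nM
Compound 3 `COc1cc(C(c2ccc(O)c(OC)c2)[C@@H](C)C(C)C)ccc1O` gives 20000 nM

In a functional assay on HL-60 cells (Homo sapiens) for cytotoxicity, read by WST assay, with a stated time of 48 h (on this read-out lower numbers stand for stronger inhibition and higher numbers for weaker inhibition), compound 3 gives 20000 nM, level with its nearest neighbour within the scatter: a 1.9-fold lower number from compound 2 to compound 3 (0.28 log units; within the scatter). The step to it from the methoxy compound is larger and lies beyond the scatter: a 4.1-fold lower number from compound 1 to compound 3 (0.61 log units; beyond the scatter).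

Compound 4 `COC[C@@H](C)[C@@H](C)C(c1ccc(O)c(OC)c1)c1ccc(O)c(OC)c1` carries this change: 2-(methoxymethyl)-1-methylpropyl in place of 1,2-dimethylpropyl on a saturated chain carbon bound to two aromatic carbons. It is 2-(methoxymethyl)-1-methylpropyl in place of 1,2-dimethylpropyl, so the swap of methoxy for hydrogen runs the other way, and that modest step is the guide. For the measured compounds named here, no measured step covers the defined stereocentres, so the range stays wide.

A higher number is therefore expected in this assay, with an estimated size of a 3.3-fold higher number from compound 3 to compound 4 (0.51 log units; beyond the scatter). The estimate for compound 4 is 65000 nM, with an expected range of 30000 nM to 130000 nM.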

Compound 4, half-maximal inhibitory concentration: 85000 nM
The estimate for compound 4 lay 1.3-fold (0.12 log units) below the measured number; low and high end bracket the measured number.
By their numbers in this assay, from the lowest: compounds 3 and 2 (each within the scatter of the next); then compounds 1 and 4 (each within the scatter of the next).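

In this assay, the methoxy chain with the opposite drawn configuration again gives a clearly higher number than the plain chain (a 4.3-fold higher number from compound 3 to compound 4 (0.63 log units; beyond the scatter)) and the fluoro chain (a 2.2-fold higher number from compound 2 to compound 4 (0.35 log units; beyond the scatter)). The cost of the methoxy therefore appears in both mirror-image forms. Inverting both stereocentres moves the number by no more than the scatter (a 1.0-fold higher number from compound 1 to compound 4 (0.02 log units; within the scatter)), a clean comparison of configuration alone: the fact that compounds 1 and 4 differ only in the configuration as drawn.

Forms with only one stereocentre inverted remain open. So does the effect of an amine or a carboxylic acid at the chain end.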